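The source may report more compounds than this note shows. Statements on the series, on what has been measured and on what is new or still open speak of the compounds shown alone.

In a functional assay on BGC-823 cells (Homo sapiens) for antiproliferative activity, read by MTT assay, with a stated time of 24 h (a lower number here means a stronger inhibitor, a higher number a weaker inhibitor), compound 1 `c1ccc(CSc2nnc(-c3ccc4c(c3)OCCO4)n2-c2ccccc2)cc1` gives 73400 nM and serves as the reference for this small set. Compound 2 `O=[N+]([O-])c1cccc(CSc2nnc(-c3ccc4c(c3)OCCO4)n2-c2ccccc2)c1` gives 30100 nM with nitro in place of hydrogen on an aromatic carbon, which amounts to a 2.4-fold lower number from compound 1 to compound 2 (0.39 log units; beyond the scatter) on this read-out. For compound 3 `Cc1ccccc1CSc1nnc(-c2ccc3c(c2)OCCO3)n1-c1ccccc1` the assay returns > 100000 nM which is a limit and not a number. Its standing is therefore known from one side only, with an at least 3.3-fold higher number from compound 2 to compound 3 (0.52 log units; beyond the scatter) as the clearest statement about it.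

Compound 4 `Fc1ccccc1CSc1nnc(-c2ccc3c(c2)OCCO3)n1-c1ccccc1` keeps all of compound 3 except one place, where fluoro in place of methyl on an aromatic carbon describes fluoro in place of methyl on an aromatic carbon, ortho to a large group. Among the compounds with values here, no measured step makes this exchange directly. The nearest guides are an at least 1.3-fold higher number from compound 1 to compound 3 (0.13 log units; that floor lies within the scatter) and a 2.4-fold lower number from compound 1 to compound 2 (0.39 log units; beyond the scatter) and neither is large, so compound 4 is expected to sit close to compound 1 at 73400 nM in this assay. The expected change is a modest step to a lower number, estimated as an at least 1.4-fold lower number from compound 3 to compound 4 (0.15 log units; that floor lies within the scatter) and left open on one side by the limit. For compound 4 the estimated value is 70000 nM with an expected range from 28000 nM to 140000 nM at the upper end.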

Compound 4, half-maximal inhibitory concentration: 18600 nM
Compound 4: middle estimate off by 3.8-fold (0.58 log units), on the high side; the measured number lies below the stated range.
By their numbers in this assay, from the lowest: compounds 4 and 2 (each within the scatter of the next); then compound 1. At a limit, above all of these: compound 3.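

In this assay, the aromatic carbon ortho to a large group proves able to carry a real gain, which the methyl of compound 3 gave no sign of: fluoro in place of hydrogen there gives a 3.9-fold lower number from compound 1 to compound 4 (0.60 log units; beyond the scatter), and fluoro in place of methyl gives an at least 5.3-fold lower number from compound 3 to compound 4 (0.73 log units; beyond the scatter). So the outcome at this one place depends on which single atom or group occupies it, and a fluoro here brings the benzyl series level with the nitro of compound 2, as 2-fluorophenyl in place of 3-nitrophenyl gives a 1.6-fold lower number from compound 2 to compound 4 (0.21 log units; within the scatter), and that step sets neither compound ahead of the other. The step from the methyl to the fluoro is only a floor because compound 3 stands at a limit and not at a number: the limit of > 100000 nM in this assay, at which 1 of the 4 values shown sits.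

From the compounds shown here alone, whether the gain belongs to fluoro alone, or would also appear with chloro, bromo or methoxy at this same place, remains open. The compounds shown also leave open what a nitrile or an amine would do on this ring, and whether any such group could carry the series clearly past compound 2 and compound 4.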